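Swapping a Chlorobenzyl Arm for an Acetamidoethyl Arm

This account rests on a few compounds, and the source may have more. Where it says the series, first, only, none or still open, it means among the compounds named here.

Measured compounds:
compound 1 `CCN1CCN(Cc2c(OC)cc(Oc3cccc(Nc4ccccc4)c3)cc2OC)CC1` — > 20000 nM
compound 2 `COc1ccc(CCCNCc2c(OC)cc(Oc3ccc(Nc4ccccc4)cc3)cc2OC)cc1` — 14600 nM
compound 3 `COc1cc(Oc2cccc(Nc3ccccc3)c2)cc(OC)c1CNCc1ccc(Cl)cc1` — 6340 nM

In a functional assay on SW-620 cells (Homo sapiens) for inhibition, read by MTT assay, with a stated time of 72 h (a higher number here means a weaker inhibitor, a lower number a stronger inhibitor), compound 3 stands lowest of the two numbers recorded; the nearest is compound 2, which gives 14600 nM, a gap beyond the scatter. For compound 1 the assay reports only a limit, > 20000 nM, and no number. Compound 4 `COc1cc(Oc2cccc(Nc3ccccc3)c2)cc(OC)c1CNCCNC(C)=O` has not yet been measured in this assay. It differs from compound 3 in one place: acetamidomethyl in place of 4-chlorophenyl on a saturated chain carbon bound to an amine nitrogen. Among the measured compounds shown here, only one measured step touches this position, the change from the 4-ethylpiperazin-1-yl group to the (4-chlorobenzyl)amino group, an at least 3.1-fold lower number from compound 1 to compound 3 (0.49 log units; beyond the scatter), which shows that the group on this chain carbon matters for this assay. That step, however, did not test the removal of the 4-chlorophenyl ring in favour of a short acetamidomethyl chain, so direction can only be judged cautiously. Compound 4 is expected to give a higher number than compound 3, an estimated step of a 2.4-fold higher number from compound 3 to compound 4 (0.37 log units; beyond the scatter). The estimated value for compound 4 is 15000 nM, within a range of 5000 nM to 40000 nM.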

Compound 4, half-maximal inhibitory concentration: 11900 nM
For compound 4 the middle estimate is 1.3-fold (0.10 log units) above the measured one, and the stated range covers the measured number.
By their numbers in this assay, from the lowest: compounds 3, 4 and 2 (each within the scatter of the next, the first and the last beyond it). At a limit, above all of these: compound 1.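

Among the compounds shown here, the step of a 1.9-fold higher number from compound 3 to compound 4 (0.27 log units; within the scatter) is the first to change only the group on a saturated chain carbon bound to an amine nitrogen, while the amine stays in place. It shows that 4-chlorophenyl can give way to acetamidomethyl, an open chain with no ring and no chlorine, without a shift beyond the scatter. The second step, an at least 1.6-fold lower number from compound 1 to compound 4 (0.22 log units; that floor lies within the scatter), gives only a floor and no true size, and compound 1 carries only a limit: the limit of > 20000 nM in this assay, at which 1 of the 4 values shown sits.

As far as these compounds go, it remains open what a plain benzyl without chlorine, a longer chain ending in the same acetamide, or a chain ending in a free primary amine or a carboxylic acid would give at this position. Compound 2 differs from compound 3 and compound 4 in more than one place, so it cannot settle this.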